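A few compounds are considered here, and "the series" means these few. Any claim that something is new, unique, unknown or untested is made for them only; others in the source may bear on it.

In an ADME assay on microsomes from liver (Homo sapiens) for metabolic stability, read by LC-MS, with a stated time of 30 min, tested at 1 uM (on this read-out lower numbers stand for a less stable compound and higher numbers for a more stable compound), compound 1 `O=C(NCc1ccc(S(=O)(=O)c2ccccc2)cc1)c1nc2cnccc2[nH]1` gives 73%, compound 2 `O=C(NCc1ccc(S(=O)(=O)c2ccccc2)cc1)c1nc2ccncc2s1` gives 68% and compound 3 `O=C(NCc1ccc(S(=O)(=O)c2ccccc2)cc1)c1ccc2nccn2c1` gives 77%, so compound 3 lies within the scatter of both others. Compound 4 `O=C(NCc1ccc(S(=O)(=O)c2ccccc2)cc1)c1cn2ccnc2cn1` differs from compound 3 by a group of 9 heavy atoms (6 carbon, 3 nitrogen; one five-membered aromatic ring with 2 hetero atoms, one six-membered aromatic ring with 2 hetero atoms) in place of a group of 9 heavy atoms (7 carbon, 2 nitrogen; one five-membered aromatic ring with 2 hetero atoms, one six-membered aromatic ring with 1 hetero atom), on a carbonyl carbon. The bearing measurements are the other exchanges at this carbonyl carbon: a number 4 percentage points higher from compound 1 to compound 3 (within the scatter), a number 9 percentage points higher from compound 2 to compound 3 (within the scatter) and a number 5 percentage points lower from compound 1 to compound 2 (within the scatter), all within the scatter. Within the data shown here, none of the measured compounds carries a six-membered aromatic ring with 2 hetero atoms, so that feature remains untested. No step beyond the scatter is therefore expected in this assay. The estimated step is a number 4 percentage points lower from compound 3 to compound 4 (within the scatter). For compound 4 the estimated value is 73%, with an expected range of 59% to 85%.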

Compound 4, percent of the compound remaining: 87%
Beside the measured number, compound 4's estimate is 14 percentage points below it, outside the stated range (above it).
By their numbers in this assay, from the lowest: compounds 2, 1, 3 and 4 (each within the scatter of the next, the first and the last beyond it).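

In this assay, among these compounds, the group with a six-membered aromatic ring with 2 hetero atoms, on a carbonyl carbon, gives the only exchanges here beyond the scatter: a number 19 percentage points higher from compound 2 to compound 4 (beyond the scatter) and a number 14 percentage points higher from compound 1 to compound 4 (beyond the scatter). Against the nearest group the change stays within the scatter: a number 10 percentage points higher from compound 3 to compound 4 (within the scatter). Nothing available accounts for these steps.

Open, as far as these compounds go, is whether this read-out holds with a single-ring group such as pyridine on the carbonyl carbon. Also open, from the compounds shown here alone, is how an amine or a carboxylic acid on the entering group would affect it.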